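A few compounds are considered here, and "the series" means these few. Any claim that something is new, unique, unknown or untested is made for them only; others in the source may bear on it.

Measured compounds in the series:

- compound 1 `Nc1nc(Cl)c2ncn(Cc3ccccc3CCl)c2n1`: 23500 nM
- compound 2 `ClCc1ccccc1Cn1cnc2ncnc(Cl)c21`: 26900 nM
- compound 3 `ClCc1ccc(Cn2cnc3ncnc(Cl)c32)cc1`: "not determined" (no result reported)

In a functional assay on SNB-75 cells (Homo sapiens) for cytotoxicity, read by sulforhodamine B assay, with a stated time of 48 h (on this read-out lower numbers stand for stronger inhibition of growth and higher numbers for weaker inhibition of growth), compound 1 gives 23500 nM and compound 2 gives 26900 nM; the two values lie within the scatter of each other, so nothing separates them. For compound 3 this assay reported "not determined" (no result reported), so compound 3 stands nowhere on the numbers shown and offers no anchor of its own; the only bearings come from compound 1 and compound 2, both weak.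

Compound 4 `ClCc1ccc(Cn2cnc3nc(Cl)nc(Cl)c32)cc1` is the next step. It differs from compound 3 as follows: chloro in place of hydrogen on an aromatic carbon

Among the measured compounds shown here, no step between measured compounds is known for a change of this kind, so no size or direction can be read from the series. In this assay the expectation for compound 4 is therefore no step beyond the scatter from the level set by compound 1 and compound 2, a wide range allowed. Compound 4 is estimated at 25000 nM, expected between 8000 nM and 80000 nM.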

Compound 4, concentration for total growth inhibition: 3980 nM
Compound 4: middle estimate off by 6.3-fold (0.80 log units), on the high side, outside the stated range (below it).
By their numbers in this assay, from the lowest: compound 4; then compounds 1 and 2 (each within the scatter of the next).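

In this assay compound 3 has no number, and the step from it to compound 4, which gives 3980 nM, cannot be read. Nothing shown here accounts for that value. From the compounds shown here alone, what chloro in place of hydrogen contributes on its own stays open.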